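A few compounds are considered here, and "the series" means these few. Any claim that something is new, unique, unknown or untested is made for them only; others in the source may bear on it.

Compound 1 `O=C(CN1C(=O)CSC1=O)NOCc1ccccc1` and compound 2 `C=CCONC(=O)CN1C(=O)CSC1=O` share one core; compound 3 `CC(C(=O)NOCc1ccccc1)N1C(=O)S/C(=C\c2ccccc2)C1=O` and the unmeasured compound 4 `C=CCONC(=O)C(C)N1C(=O)S/C(=C\c2ccccc2)C1=O` share another, and the difference between the two cores is not broken down here.

In an ADME assay on RAW264.7 cells (Mus musculus) for cytotoxicity, read by neutral red uptake, with a stated time of 24 h (a higher number here means that more compound is tolerated, a lower number that less compound is tolerated), compound 1 gives > 128000 nM, which is a limit of the assay and not a number. In this assay compound 2 gives > 128000 nM, again only a limit. Compound 3 gives > 128000 nM in this assay, once more a limit. The change from compound 1 to compound 2 is vinyl in place of phenyl on a saturated chain carbon bound to an oxygen, and it makes a step that the two limits leave unreadable from compound 1 to compound 2. The change from compound 3 to compound 4 is vinyl in place of phenyl on a saturated chain carbon bound to an oxygen, the same change at the same place.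

Because (the limit of > 128000 nM in this assay, at which 3 of the 3 values shown sit), he expects nothing in the data to separate compound 4 from its neighbours. He therefore expects the step that the limit leaves unreadable from compound 3 to compound 4 in this assay, resting on the step from compound 1 to compound 2 and on the limit of compound 3. His estimate for compound 4 in this assay is 160000 nM, with a range from 100000 nM to 300000 nM, most likely reported again as a limit.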

Compound 4, half-maximal cytotoxic concentration: > 128000 nM
Compound 4: only a limit was reported; the forecaster's own chance of this, stated with the estimate: 85%; the middle value does not contradict the limit.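

In this assay compound 4 gives > 128000 nM, a limit of the assay and not a number. Compound 3 gives > 128000 nM, again only a limit, so no step can be read between compound 3 and compound 4. The compounds shown leave open at what concentration any of them becomes cytotoxic, and whether vinyl in place of phenyl changes that: the limit of > 128000 nM in this assay, at which 4 of the 4 values shown sit.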